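Series notes: swapping the chain terminus in the hydroxypropyl amides

The source may report more compounds than this note shows. Statements on the series, on what has been measured and on what is new or still open speak of the compounds shown alone.

For the measured compounds named here, the three measured members share one core and differ only at the end of the chain attached through an oxygen on the aromatic ring. In a functional assay on PANC-1 cells (Homo sapiens) for inhibition, read by MTT assay, with a stated time of 24 h, tested at 10 uM (on this read-out higher numbers stand for more inhibition at the one concentration tested (going by the name of the read-out) and lower numbers for less inhibition), compound 1 `CC(C)=CCC/C(C)=C/CC1Cc2c(OCc3ccccc3)cc(=O)n(CCCO)c2CC1(C)C` gives 1.5%. Compound 2 `CC(C)=CCC/C(C)=C/CC1Cc2c(OCCCNS(=O)(=O)c3ccc(C(F)(F)F)cc3)cc(=O)n(CCCO)c2CC1(C)C` gives 0% in this assay, and compound 3 `CC(C)=CCC/C(C)=C/CC1Cc2c(OCCCNS(=O)(=O)c3ccc(Br)cc3)cc(=O)n(CCCO)c2CC1(C)C` gives 0%. Compound 3 stands level with compound 2 and together they are the lowest of the three numbers; compound 1 is higher by an amount that lies within the scatter, so nothing separates the three on this read-out.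

Going by the values given here, the only measured step, no change at the digits printed from compound 2 to compound 3 (within the scatter), concerns bromo in place of trifluoromethyl on an aromatic carbon and does not exceed the scatter.

Compound 4 `CC(C)=CCC/C(C)=C/CC1Cc2c(OCCCOc3ccc(Cl)cc3)cc(=O)n(CCCO)c2CC1(C)C` is reached from compound 3 by the change (4-chlorophenoxy in place of ((4-bromophenyl)sulfonyl)amino on a saturated chain carbon, three bonds along the chain from an oxygen on an aromatic ring). Among the compounds with values here, no measured step touches the chain terminus itself, so the measured series gives no direct precedent; what it does show is that every variation made so far leaves the read-out near zero. The expected step of a number 3 percentage points higher from compound 3 to compound 4 (within the scatter) is therefore none beyond the scatter. For compound 4 the estimate in this assay is 3%, with a range from 0% to 15%.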

Compound 4, a percentage reported as inhibition, at one concentration (the size of the read-out at that concentration, not a potency): 0%
Compound 4: middle estimate off by 3 percentage points, on the high side, and the stated range covers the measured number.
By their numbers in this assay, from the lowest: compounds 2, 3, 4 and 1 (each within the scatter of the next).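

In this assay, for the compounds shown here, the step of no change at the digits printed from compound 3 to compound 4 (within the scatter) is the first measured exchange of the whole terminal group, with 4-chlorophenoxy in place of ((4-bromophenyl)sulfonyl)amino, and the entering group has 0 hydrogen-bond donors and a different halogen on its ring. The step of a number 1.5 percentage points lower from compound 1 to compound 4 (within the scatter) brings in 2-(4-chlorophenoxy)ethyl in place of phenyl at the same position and also stays within the scatter, so in this assay the aryl ether terminus cannot be told apart from either the sulfonyl-linked terminus of compound 3 or the phenyl terminus of compound 1. Nothing available accounts for these flat numbers.

On these data alone, whether any group at this position can lift the read-out clear of the scatter remains open, since a terminal primary amine or a carboxylic acid on the same chain would test a kind of terminus absent from these four compounds. As far as these compounds go, it is also open whether the near-zero numbers hold at other concentrations, as a single-concentration reading gives no potency for any of them.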